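A few compounds are considered here, and "the series" means these few. Any claim that something is new, unique, unknown or untested is made for them only; others in the source may bear on it.

Three amides built on the shared core of compound 1 `O=C(Nc1cccc(/C=C/C(=O)c2nc3ccccc3[nH]2)c1)c1ccc(Cl)cc1` have been tested in a functional assay on 143B cells (Homo sapiens) for antiproliferative activity, read by MTT assay, with a stated time of 48 h; a lower number here means a stronger inhibitor, a higher number a weaker inhibitor. Compound 1 gives 7440 nM. Compound 2 `O=C(/C=C/c1cccc(NC(=O)c2ccccc2Br)c1)c1nc2ccccc2[nH]1` gives 6050 nM in this assay, and compound 3 `O=C(Nc1cccc(/C=C/C(=O)c2nc3ccccc3[nH]2)c1)c1cccc(Br)c1` gives 4620 nM. Compound 3 holds the lowest of the three numbers, yet its gaps to the other two lie within the scatter: a 1.3-fold lower number from compound 2 to compound 3 (0.12 log units; within the scatter), and a 1.6-fold lower number from compound 1 to compound 3 (0.21 log units; within the scatter). The remaining pair behaves the same way: a 1.2-fold lower number from compound 1 to compound 2 (0.09 log units; within the scatter). Compound 4 `Cc1cccc(C(=O)Nc2cccc(/C=C/C(=O)c3nc4ccccc4[nH]3)c2)c1` differs from compound 3 by methyl in place of bromo on an aromatic carbon. Among the compounds with values here, no measured pair shows a halogen giving way to a methyl; the three steps available only exchange one halogenated phenyl for another, and none of them moves the number in this assay beyond the scatter. On that basis the step from compound 3 to compound 4 is expected to stay within the scatter as well, a 1.2-fold higher number from compound 3 to compound 4 (0.08 log units; within the scatter). Compound 4 is therefore estimated at 5500 nM in this assay, with a range from 2000 nM to 15000 nM.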

Compound 4, half-maximal inhibitory concentration: 4880 nM
Estimate against measurement, compound 4: 1.1-fold (0.05 log units) above, and the stated range covers the measured number.
By their numbers in this assay, from the lowest: compounds 3, 4, 2 and 1 (each within the scatter of the next).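

In this assay, within the data shown here, the change from 3-bromophenyl to 3-methylphenyl is the first exchange of a halogen for a carbon group at this position, and it gives a 1.1-fold higher number from compound 3 to compound 4 (0.02 log units; within the scatter). The two other steps to the new amide read the same way, with a 1.2-fold lower number from compound 2 to compound 4 (0.09 log units; within the scatter) and a 1.5-fold lower number from compound 1 to compound 4 (0.18 log units; within the scatter), so methyl on this ring separates from none of the halogenated phenyl amides, and all four compounds remain within the scatter of one another. Nothing measured alongside these numbers accounts for this result.

Going by these compounds, it remains open whether an amine, a carboxylic acid or a longer chain such as propyl in place of the methyl would move the number beyond the scatter. Also open, on these data alone, is whether methyl in place of the bromo of 2-bromophenyl would behave as it does in 3-methylphenyl.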